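Replacing an indazole with cyclohexyl: expected lipophilicity of compound 4

The source may report more compounds than this note shows. Statements on the series, on what has been measured and on what is new or still open speak of the compounds shown alone.

Measured compounds in a physicochemical assay for lipophilicity, at pH 7.4; on this read-out lower numbers stand for lower lipophilicity and higher numbers for higher lipophilicity:
- compound 1, `CNC(=O)c1cc(C(=O)NC2CC2)cn(Cc2cccc(OC)c2)c1=O`: 3
- compound 2, `CNC(=O)c1cc(C(=O)NC2CC2)cn(Cc2ccc(F)cc2)c1=O`: 3.2
- compound 3, `CNC(=O)c1cc(C(=O)NC2CC2)cn(Cc2cccc3cn[nH]c23)c1=O`: 2.2

Compound 3 stands lowest of the three. The nearest value belongs to compound 1, and the step of a number 0.80 log units lower from compound 1 to compound 3 (beyond the scatter) lies beyond the scatter. The gap to compound 2 is wider still, as a number 1.00 log units lower from compound 2 to compound 3 (beyond the scatter) shows, while a number 0.20 log units higher from compound 1 to compound 2 (within the scatter) stays within the scatter.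

Compound 4, `CNC(=O)c1cc(C(=O)NC2CC2)cn(CC2CCCCC2)c1=O`, has not yet been measured in this assay. It differs from compound 3 in one place: cyclohexyl in place of 1H-indazol-7-yl on a saturated chain carbon bound to an aromatic nitrogen. The group that leaves carries 1 hydrogen-bond donor and 1 hydrogen-bond acceptor; the group that enters carries none.

The two steps that bear on this change are the ones into compound 3, a number 0.80 log units lower from compound 1 to compound 3 (beyond the scatter) and a number 1.00 log units lower from compound 2 to compound 3 (beyond the scatter), in which the indazole arrived. Compound 4 removes that indazole again, so the step in this assay is expected to run upward, roughly reversing those two, as a number 1.30 log units higher from compound 3 to compound 4 (beyond the scatter). Compound 4 is therefore estimated at 3.5, with a range from 2.9 to 4.1.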

Compound 4, distribution coefficient: 4
Compound 4: middle estimate off by 0.50 log units, on the low side, and the stated range covers the measured number.
By their numbers in this assay, from the lowest: compound 3; then compounds 1 and 2 (each within the scatter of the next); then compound 4.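

In this assay this position now covers a wider range than the aromatic groups alone showed, with a number 1.80 log units higher from compound 3 to compound 4 (beyond the scatter) when cyclohexyl takes the place of 1H-indazol-7-yl. The non-aromatic ring also stands apart from the two substituted phenyl groups, which had remained within the scatter of each other: a number 0.80 log units higher from compound 2 to compound 4 (beyond the scatter) for the change from 4-fluorophenyl and a number 1.00 log units higher from compound 1 to compound 4 (beyond the scatter) for the change from 3-methoxyphenyl. Nothing available here accounts for the size of these steps.

The compounds shown do not separate the loss of the aromatic rings from the loss of the ring nitrogens, a question that a naphthyl group at this place would address. Where a piperidine or a hydroxycyclohexyl group would fall also stays open.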